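The source may report more compounds than this note shows. Statements on the series, on what has been measured and on what is new or still open speak of the compounds shown alone.

Measured compounds:
Compound 1, `COc1ccc(-n2c(Nc3nc(-c4ccc([N+](=O)[O-])cc4)cs3)n[nH]c2=S)cc1`, gives 300 mg/kg.
Compound 2, `COc1ccccc1-n1c(Nc2nc(-c3ccc(Cl)cc3)cs2)n[nH]c1=S`, gives 100 mg/kg.
Compound 3, `Cc1ccc(-n2c(Nc3nc(-c4ccc(Cl)cc4)cs3)n[nH]c2=S)cc1`, gives 300 mg/kg.

All three were tested in a functional assay on the whole organism (strain Swiss albino) for inhibition, with Mus musculus as the target, with a stated time of 4 h; on this read-out higher numbers stand for an effect only at larger amounts of compound and lower numbers for an effect already at smaller amounts. Compound 3 stands level with compound 1 at the digits shown, and the two of them share the highest number of the three. Within the data shown here, compound 2 sits apart from them: the one measured step, a 3.0-fold higher number from compound 2 to compound 3 (0.48 log units; beyond the scatter), concerns the aryl group on the aromatic nitrogen and is beyond the scatter.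

Compound 4, `Cc1ccc(-n2c(Nc3nc(-c4ccc([N+](=O)[O-])cc4)cs3)n[nH]c2=S)cc1`, has not yet been measured. It differs from compound 3 in one place: nitro in place of chloro on an aromatic carbon. Among the measured compounds shown here, no measured pair differs in only this way, so no single step speaks to it directly. The step from compound 2 to compound 3 changes a different part of the molecule and does not bear on it. What can be said is that compound 1, which carries the nitro group, and compound 3, which carries the chloro group, give numbers that do not differ at the digits shown, although they also differ in the aryl group on the nitrogen.

On that basis, compound 4 is expected to give 300 mg/kg, within 150 mg/kg to 600 mg/kg, the step of no change at the digits printed from compound 3 to compound 4 (within the scatter) being expected to lie within the scatter.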

Compound 4, minimum effective dose: 300 mg/kg
Compound 4: middle estimate and measured number agree at the digits printed; measured number inside the range.
By their numbers in this assay, from the lowest: compound 2; then compounds 1, 3 and 4 (each within the scatter of the next).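

In this assay, the change from 4-chlorophenyl to 4-nitrophenyl can now be read directly, with the aryl group on the nitrogen held constant: no change at the digits printed from compound 3 to compound 4 (within the scatter). Among these compounds, at this place, on an aromatic carbon para to a large group, the read-out therefore does not separate chloro, with 1 heavy atom and 0 hydrogen-bond acceptors, from nitro, with 3 heavy atoms and 2 hydrogen-bond acceptors, and the new compound also gives a first direct reading of methyl in place of methoxy on an aromatic carbon, with the nitro group held constant: no change at the digits printed from compound 1 to compound 4 (within the scatter). No measurement is available that could account for either result.

The compounds shown leave open whether a group of another kind at this place, such as an amine or a carboxylic acid, would shift the number in this assay. They also leave open whether chloro and nitro would remain level with the 2-methoxyphenyl group of compound 2 on the nitrogen, since only the chloro member of that pair is shown.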